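Furan-3-yl to iodo, starting from a limit

The source may report more compounds than this note shows. Statements on the series, on what has been measured and on what is new or still open speak of the compounds shown alone.

Values in a functional assay on K562 cells (Homo sapiens), read by MTT assay, with a stated time of 72 h (a higher number here means a weaker inhibitor, a lower number a stronger inhibitor), as follows:
- compound 1 `CNc1ncnc2c1c(-c1ccoc1)cn2[C@@H]1O[C@H](CO)[C@@H](O)[C@H]1O` gives > 20000 nM (a limit)
- compound 2 `CN(C)c1ncnc2c1c(-c1ccoc1)cn2[C@@H]1O[C@H](CO)[C@@H](O)[C@H]1O` gives 14900 nM (a number)
- compound 3 `Cc1ncnc2c1c(-c1ccoc1)cn2[C@@H]1O[C@H](CO)[C@@H](O)[C@H]1O` gives > 20000 nM (a limit)

For compound 3 the reading of > 20000 nM is a limit and not a number. This is the limit of > 20000 nM in this assay, at which 2 of the 3 values shown sit, and compound 3 shares it with compound 1.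

Compound 4 `Cc1ncnc2c1c(I)cn2[C@@H]1O[C@H](CO)[C@@H](O)[C@H]1O` carries iodo in place of furan-3-yl on an aromatic carbon. For the measured compounds named here, all three measured compounds keep furan-3-yl, so no measured step covers this exchange. Swapping among methyl, methylamino and dimethylamino gives an at least 1.3-fold lower number from compound 1 to compound 2 (0.12 log units; that floor lies within the scatter) and an at least 1.3-fold higher number from compound 2 to compound 3 (0.12 log units; that floor lies within the scatter) and a step that the two limits leave unreadable from compound 1 to compound 3 and lends no size to carry over.

The data therefore support no firm direction. A reading close to the limit is expected, with a fair chance that only a limit is reported. Going by the values given here, the expectation leans on compound 2 at 14900 nM as the one number. The expected change is an at least 1.6-fold lower number from compound 3 to compound 4 (0.22 log units; that floor lies within the scatter) and it remains a rough estimate. For compound 4 the estimate is 12000 nM with an expected range from 1500 nM to 30000 nM in this assay as the read-out.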

Compound 4, half-maximal inhibitory concentration: > 20000 nM
Compound 4 gave a limit, no number; the forecaster's own chance of this, stated with the estimate: 45%; middle value at least 1.6-fold (0.22 log units) from the limit.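

In this assay compound 4 gives > 20000 nM, a limit and not a number. Compound 3 also gives a limit, so no step can be read between compound 3 and compound 4, and the result joins the rest of the series: the limit of > 20000 nM in this assay, at which 3 of the 4 values shown sit.

The compounds shown leave open whether iodo in place of furan-3-yl changes the read-out at all.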